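A few compounds are considered here, and "the series" means these few. Any claim that something is new, unique, unknown or untested is made for them only; others in the source may bear on it.

Working notes on the series built on the core of compound 1 `Cc1nc(SCC(=O)Nc2nc(-c3ccc(Cl)cc3)cs2)n(Nc2ccccc2)c1C`. Within the data shown here, in a functional assay on UO-31 cells (Homo sapiens) for antiproliferative activity, read by sulforhodamine B assay, with a stated time of 48 h (a higher number here means a weaker inhibitor of growth, a lower number a stronger inhibitor of growth), compound 1 gives 37700 nM, which is the only finite number available so far. Compound 2 `Cc1ccc(Nn2c(SCC(=O)Nc3nc(-c4ccccc4)cs3)nc(C)c2C)cc1` returns > 100000 nM in this assay, a limit of the assay rather than a number; this is the limit of > 100000 nM in this assay, at which 1 of the 2 values shown sits. Among the measured compounds shown here, no pair of measured compounds differing in a single place exists here, so the size of any one change has not yet been observed in this assay. Compound 3 `COc1ccc(Nn2c(SCC(=O)Nc3nc(-c4ccc(Cl)cc4)cs3)nc(C)c2C)cc1` differs from compound 1 in one place: methoxy in place of hydrogen on an aromatic carbon. For the measured compounds named here, with no measured step to anchor it, the step from compound 1 to compound 3 is expected to be a 1.6-fold higher number from compound 1 to compound 3 (0.20 log units; within the scatter), leaning toward weaker growth inhibition, with a real chance that only a limit is returned. The estimate for compound 3 in this assay is 60000 nM, within a range of 20000 nM to 180000 nM.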

Compound 3, concentration for total growth inhibition: > 100000 nM
Compound 3: no number, only a limit (the forecaster's own chance of this, stated with the estimate: 40%); at least 1.6-fold (0.22 log units) between middle value and limit.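

In this assay, among these compounds, methoxy in place of hydrogen on an aromatic carbon, para to a large group, gives an at least 2.6-fold higher number from compound 1 to compound 3 (0.42 log units; beyond the scatter), the first single-place step, and it runs toward weaker growth inhibition. Going by these compounds, compound 3 returns a limit of the assay and not a number (> 100000 nM), so this step is a lower bound and its true size remains unknown. Among the compounds shown here, compound 1 therefore stays the only compound here with a finite value, and the series now sits largely at the assay's ceiling: the limit of > 100000 nM in this assay, at which 2 of the 3 values shown sit.

On these data alone, whether a fluoro, hydroxyl or amine group at this same position would keep a finite value remains open. The compounds shown also do not tell whether the loss is specific to methoxy or extends to other groups in place of this hydrogen.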